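The source may hold more compounds than are shown below. What is called first, only, known or untested is meant among the compounds shown, and "the series" means these compounds.

Compound 1 `COc1cc(N(Cc2nc3ccccc3[nH]2)C(=O)c2ccccc2)cc(OC)c1OC` carries a hydrogen on the aromatic carbon where compound 2 `COc1cc(N(Cc2nc3ccccc3[nH]2)C(=O)c2ccc(C)cc2)cc(OC)c1OC` carries a methyl. In a functional assay on PC-3 cells (Homo sapiens) for inhibition, read by MTT assay, with a stated time of 48 h (on this read-out lower numbers stand for stronger inhibition and higher numbers for weaker inhibition), compound 1 gives a limit of the assay rather than a number, > 50000 nM. In this assay compound 2 gives 42000 nM, the only number shown in this set. Among the measured compounds shown here, the one other value shown is the limit of > 50000 nM in this assay, at which 1 of the 2 values shown sits. The step of an at least 1.1-fold lower number from compound 1 to compound 2 (0.07 log units; that floor lies within the scatter) therefore has only a floor, and that floor lies within the scatter, so it tells nothing beyond the scatter about what a change at this aromatic carbon does.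

Compound 3 `COc1cc(N(Cc2nc3ccccc3[nH]2)C(=O)c2ccc(C(C)(C)C)cc2)cc(OC)c1OC` differs from compound 2 by tert-butyl in place of methyl on an aromatic carbon. For the measured compounds named here, the only measured step that bears on it is the one from compound 1 to compound 2, a change at the same aromatic carbon, and it was no more than a floor within the scatter. For compound 3 the expected step in this assay is a 1.2-fold lower number from compound 2 to compound 3 (0.08 log units; within the scatter), a movement not clearly beyond the scatter, with some chance that only a limit is reported. Compound 3 is thus estimated at 35000 nM, within 12000 nM to 100000 nM.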

Compound 3, half-maximal inhibitory concentration: 46000 nM
Estimate against measurement, compound 3: 1.3-fold (0.12 log units) below; measured number inside the range.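

In this assay, among the compounds shown here, the change from 4-methylphenyl to 4-(tert-butyl)phenyl gives a 1.1-fold higher number from compound 2 to compound 3 (0.04 log units; within the scatter), the first comparison at this aromatic carbon that rests on two numbers rather than on a number and a limit, and it shows that going from methyl to the larger tert-butyl leaves the read-out within the scatter. With hydrogen at the same carbon, the comparison remains only a floor, an at least 1.0-fold lower number from compound 1 to compound 3 (0.03 log units; that floor lies within the scatter), and so it shows nothing beyond the scatter for tert-butyl in place of hydrogen. This comparison can go no further than a floor because compound 1 gives a limit of the assay and not a number: the limit of > 50000 nM in this assay, at which 1 of the 3 values shown sits.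

On these data alone, it remains open whether any group at this carbon would move the number beyond the scatter, for example an amine, a carboxylic acid or a methoxy group in place of methyl or tert-butyl. Also open, as far as these compounds go, is how far a change elsewhere on the shared core would move the number in this assay.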